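The compounds below may be only part of what the source reports. "The series", "measured", "known", "first", "only" and "open" are said of these compounds alone.

Measured compounds:
compound 1 `Oc1cccc2c1CCCC2c1c[nH]cn1` gives 30.9 nM
compound 2 `CCS(=O)(=O)Nc1cccc2c1CCCC2(O)c1c[nH]cn1` gives < 10000 nM
compound 3 `CS(=O)(=O)Nc1cccc2c1OCCC2c1c[nH]cn1` gives 1150 nM

All three were tested in an assay on isolated protein for binding affinity to Alpha-1D adrenergic receptor (Rattus norvegicus), read by radioligand binding; a lower number here means a stronger inhibitor, a higher number a weaker inhibitor. Compound 1 stands lowest of the two numbers measured. The nearest is compound 3, whose number in this assay is higher by a gap that lies beyond the usual scatter. For compound 2 the assay reports only a limit, not a number; this is the limit of < 10000 nM in this assay, at which 1 of the 3 values shown sits. Compound 4 `CN(C)S(=O)(=O)Nc1cccc2c1CCCC2c1c[nH]cn1` has not been measured. It differs from compound 1 in one place: (dimethylsulfamoyl)amino in place of hydroxy on an aromatic carbon. Going by the values given here, no step between measured compounds touches this change, so the expected step from compound 1 to compound 4 is a 16-fold higher number from compound 1 to compound 4 (1.21 log units; beyond the scatter), towards a higher number. Compound 4 is estimated at 500 nM, with a range from 100 nM to 5000 nM.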

Compound 4, inhibition constant: 1580 nM
Beside the measured number, compound 4's estimate is 3.2-fold (0.50 log units) below it; the measured number falls inside the stated range.
By their numbers in this assay, from the lowest: compound 1; then compounds 3 and 4 (each within the scatter of the next).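

In this assay, going by these compounds alone, (dimethylsulfamoyl)amino in place of hydroxy on the aromatic carbon gives a 51-fold higher number from compound 1 to compound 4 (1.71 log units; beyond the scatter) and is the first change here that can be read at a single place on the shared core. The position therefore does not hold the number of compound 1 with this group, although compound 4 still gives a measured number and not a limit. Nothing measured here explains the step. Within the data shown here, with only this one change at the position, it stays open how an amine, a methoxy group or a methanesulfonylamino group on the same carbon would read.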